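The source may hold more compounds than are shown below. What is called first, only, known or untested is meant among the compounds shown, and "the series" means these compounds.

Measured compounds:
Compound 1 `CCC(C)NC(=C\C(=O)/C=C/c1ccc(O)c(OC)c1)/C=C/c1ccc(O)c(OC)c1` gives > 25000 nM in a functional assay on Caco-2 cells (Homo sapiens) for inhibition, read by MTT assay, with a stated time of 72 h (a lower number here means a stronger inhibitor, a higher number a weaker inhibitor), which is a limit of the assay rather than a number.
Compound 2 `CCC(C)NC(=C\C(=O)/C=C/c1ccc(O)cc1)/C=C/c1ccc(O)cc1` gives 9400 nM in this assay.
Compound 3 `CC(=O)Oc1ccc(/C=C/C(=O)/C=C(/C=C/c2ccc(OC(C)=O)cc2)NCC(C)C)cc1` gives > 25000 nM in this assay, again only a limit.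

Compound 1 therefore stands at the limit of > 25000 nM in this assay, at which 2 of the 3 values shown sit; its value is known only as a limit, not as a number. Compound 4 `COc1cc(/C=C/C(=O)/C=C(/C=C/c2ccc(O)c(OC)c2)NCC(C)C)ccc1O` differs from it by isobutyl in place of sec-butyl on an amine nitrogen. Among the compounds with values here, no step between two measured compounds that differ in only one place is known. Compound 3, which also carries the isobutyl group, sits at the limit as well. In this assay no change beyond the scatter is expected from this swap. Compound 4 is expected to give 25000 nM, between 10000 nM and 60000 nM, an expected step of a number no higher from compound 1 to compound 4 (the limit leaves the size open).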

Compound 4, half-maximal inhibitory concentration: > 25000 nM
Compound 4: a limit, no number (the forecaster's own chance of this, stated with the estimate: 70%); the middle value lies on the limit itself.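

Compound 1 and compound 4 are both known only as limits, so no step can be read between them: the limit of > 25000 nM in this assay, at which 3 of the 4 values shown sit. As far as these compounds go, whether isobutyl in place of sec-butyl on an amine nitrogen changes inhibition at all stays open.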